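The source may hold more compounds than are shown below. What is called first, only, known or untested is meant among the compounds shown, and "the series" means these compounds.

Measured compounds:
Compound 1, `COc1ccc(-c2ccnc(Nc3ccc(C(=O)O)cc3)n2)cc1`, gives 20300 nM in a functional assay on A549 cells (Homo sapiens) for cytotoxicity, read by MTT assay, with a stated time of 72 h; on this read-out lower numbers stand for stronger inhibition and higher numbers for weaker inhibition.
Compound 2, `COc1ccc(-c2ccnc(Nc3cccc(C(N)=O)c3)n2)cc1`, gives 6700 nM.
Compound 3, `Cc1csc(-c2ccnc(Nc3ccc(C(=O)O)cc3)n2)c1`, gives 18200 nM.

Among these three, compound 2 has the lowest number in this assay; the nearest is compound 3 and the furthest is compound 1, and both of those gaps are beyond the scatter. Compound 1 and compound 2 rest on different cores, and the difference between the two cores is not broken down here.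

One change joins compound 1 to compound 3: 4-methylthiophen-2-yl in place of 4-methoxyphenyl on an aromatic carbon. In this assay this gave a 1.1-fold lower number from compound 1 to compound 3 (0.05 log units; within the scatter).

Compound 4, `Cc1csc(-c2ccnc(Nc3cccc(C(N)=O)c3)n2)c1`, has not yet been measured in this assay. It arises from compound 2 by the same change, made at the same place: 4-methylthiophen-2-yl in place of 4-methoxyphenyl on an aromatic carbon.

Because a 1.1-fold lower number from compound 1 to compound 3 (0.05 log units; within the scatter) lay within the scatter, the step from compound 2 to compound 4 is expected to be of about that size, a 1.1-fold lower number from compound 2 to compound 4 (0.03 log units; within the scatter). On that basis compound 4 is estimated at 6200 nM, with the likely range running from 3000 nM to 13000 nM.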

Compound 4, half-maximal inhibitory concentration: > 100000 nM
Compound 4 ended at the assay's limit (the forecaster's own chance of this, stated with the estimate: 5%); at least 16-fold (1.20 log units) between middle value and limit.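

In this assay compound 4 gives > 100000 nM, which is a limit of the assay and not a number. Putting 4-methylthiophen-2-yl in place of 4-methoxyphenyl on the second core gave an at least 14-fold higher number from compound 2 to compound 4 (1.17 log units; beyond the scatter), so the near-silent result of this change on the first core did not carry over, and the two steps differ: the same change on two cores in this assay, a 1.1-fold lower number (0.05 log units; within the scatter) from compound 1 to compound 3 and an at least 14-fold higher number (1.17 log units; beyond the scatter) from compound 2 to compound 4, at least 16-fold (1.22 log units) apart, beyond the scatter of two such steps This shows that, across these two pairs, the outcome of the change depends on the core it is made on, but it does not show what in the core is responsible, how large the step really is beyond the limit, or how the change would behave on any further core.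

The compounds shown leave open whether the difference between the cores follows from the carboxylic acid of compound 1 and compound 3, the amide of compound 2 and compound 4, or the place each group occupies. They also leave open how the same change would behave with a methyl ester or an amine at that place.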